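The source may hold more compounds than are shown below. What is called first, only, known or untested is meant among the compounds shown, and "the series" means these compounds.

Measured so far in an assay on isolated protein for inhibition of thyroid hormone receptor beta (Homo sapiens), read by fluorescence polarization; a higher number here means a weaker inhibitor, a lower number a stronger inhibitor:

compound 1 `CC(C)N(C(=O)CCNC(=O)c1ccc(S(C)(=O)=O)c([N+](=O)[O-])c1)C(C)C`: > 60000 nM
compound 2 `CC(C)N(C(=O)C1CCN(C(=O)c2ccc(S(C)(=O)=O)c([N+](=O)[O-])c2)CC1)C(C)C`: > 60000 nM
compound 3 `CC1CCN(C(=O)CCCNC(=O)c2ccc(S(C)(=O)=O)c([N+](=O)[O-])c2)CC1`: > 60000 nM

Each of these three readings is a limit of the assay, not a number. Compound 2 therefore stands at the limit of > 60000 nM in this assay, at which 3 of the 3 values shown sit, without a number of its own and without a measured step to any neighbour. The two other values shown are limits as well, so none of the three compounds can be placed above or below another; all that the series shows is that none of them reached a measurable inhibition.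

Compound 4 `CN(Cc1ccccc1)C(=O)C1CCN(C(=O)c2ccc(S(C)(=O)=O)c([N+](=O)[O-])c2)CC1` has not yet been measured. It differs from compound 2 in one place: benzyl(methyl)amino in place of diisopropylamino on a carbonyl carbon. The rest of compound 2 is kept.

For the measured compounds named here, since no measured step exists, no size of step can be taken from it. In this assay the expected change is none beyond the scatter, and the most probable outcome for compound 4 is again a limit rather than a number. The expected step is a step that the limit leaves unreadable from compound 2 to compound 4. For compound 4 the estimate in this assay is 70000 nM, with a range from 20000 nM to 200000 nM.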

Compound 4, half-maximal inhibitory concentration: > 60000 nM
Compound 4: a limit, no number (the forecaster's own chance of this, stated with the estimate: 80%); the middle value lies beyond the limit too.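

In this assay compound 4 gives > 60000 nM as a limit and not a number. For the compounds shown here, compound 2 also stands at a limit, so no step between compound 2 and compound 4 can be read. The compounds shown leave open which changes, if any, would bring inhibition into a measurable range.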